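The source may hold more compounds than are shown below. What is called first, only, known or untested is meant among the compounds shown, and "the series" means these compounds.

Compound 1 `COCCOc1cc2oc(=O)n(CCC(=O)O)c2cc1Cl` gives 31.6 nM in an assay for inhibition of kynurenine 3-monooxygenase (Homo sapiens), read by mass spectrometry, with a stated time of 1 h; on this read-out lower numbers stand for stronger inhibition and higher numbers for weaker inhibition.
Compound 2 `O=C(O)CCn1c(=O)oc2cc(OCC3CCC3)c(Cl)cc21` gives 25.1 nM in this assay.
Compound 3 `C[C@@H](Oc1cc2oc(=O)n(CCC(=O)O)c2cc1Cl)c1ccc(Cl)cn1` gives 3.16 nM in this assay.

Compound 3 stands lowest of the three numbers in this assay. Its nearest neighbour is compound 2, and the furthest is compound 1; both of those gaps lie beyond the scatter. Within the data shown here, the only measured step between compounds that differ in one place is a 1.3-fold lower number from compound 1 to compound 2 (0.10 log units; within the scatter), which swaps one saturated group for another at the ether position and changes nothing beyond the scatter.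

Compound 4 `C[C@@H](Oc1cc2oc(=O)n(CCC(=O)O)c2cc1Cl)c1ncccn1` differs from compound 3 by pyrimidin-2-yl in place of 5-chloropyridin-2-yl on a saturated chain carbon bound to an oxygen on an aromatic ring and a saturated chain carbon. Among the measured compounds shown here, no measured step touches the aromatic ring at this position, so the bearing of the data is indirect: compound 3, which carries an aromatic ring there, gives a clearly lower number than compound 1 and compound 2, which carry saturated groups, while the step from compound 1 to compound 2 shows that two saturated groups are interchangeable within the scatter. Whether one aromatic ring can replace another without cost is not shown. Since compound 4 keeps an aromatic ring at the place that set compound 3 apart, the step of a 3.2-fold higher number from compound 3 to compound 4 (0.50 log units; beyond the scatter) is expected to be modest and toward a higher number. Compound 4 is estimated at 10 nM, with a range from 3 nM to 40 nM.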

Compound 4, half-maximal inhibitory concentration: 5.01 nM
Compound 4: the middle estimate sits 2.0-fold (0.30 log units) above what was measured; the range from low to high includes it.
By their numbers in this assay, from the lowest: compounds 3 and 4 (each within the scatter of the next); then compounds 2 and 1 (each within the scatter of the next).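

In this assay, among these compounds, pyrimidin-2-yl in place of 5-chloropyridin-2-yl gives a 1.6-fold higher number from compound 3 to compound 4 (0.20 log units; within the scatter) and so shows, as the earlier compounds could not, that one aromatic ring can replace another at this position within the scatter, even with the chlorine gone and a further ring nitrogen present. The low number of compound 3 is also no longer a single case: the steps of a 5.0-fold lower number from compound 2 to compound 4 (0.70 log units; beyond the scatter) and a 6.3-fold lower number from compound 1 to compound 4 (0.80 log units; beyond the scatter) both lie beyond the scatter, so the two compounds with an aromatic ring here stand apart from the two with saturated groups, although those steps also change the size of the group on the oxygen. No evidence at hand explains how either kind of group produces these numbers.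

The compounds shown leave open whether the aromatic ring alone accounts for the gap, or whether the methyl group on the saturated chain carbon contributes, as a plain benzyl group would help to show. From the compounds shown here alone, how an amine or a carboxylic acid on the aromatic ring would fare also remains open.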